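The compounds below may be only part of what the source reports. "The series", "measured", "known", "first", "only" and "open" are said of these compounds alone.

Measured compounds:
- compound 1, `COc1cc(C)cc(-c2nn(CC#N)cc2-c2ccc(-c3cccc(C(C)=O)c3)nc2)c1` — in a functional assay on TK-10 cells (Homo sapiens) for inhibition, read by sulforhodamine B assay, with a stated time of 48 h (on this read-out lower numbers stand for higher toxicity in this test and higher numbers for lower toxicity in this test), compound 1 gives > 100000 nM, which is a limit of the assay rather than a number.
- compound 2, `Cc1cc(O)cc(-c2nn(CC#N)cc2-c2ccnc(-c3ccc(Oc4ccccc4)cc3)c2)c1` — in this assay compound 2 gives 43600 nM.
- compound 3, `COc1cc(C)cc(-c2nn(CC#N)cc2-c2ccnc(-c3ccc(N(C)C)cc3)c2)c1` — in this assay compound 3 gives > 100000 nM, again a limit of the assay and not a number.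

Among the compounds with values here, compound 3 therefore stands at the limit of > 100000 nM in this assay, at which 2 of the 3 values shown sit, so no number places it against compound 2, whose value is the only number among the three. Compound 4, `Cc1cc(O)cc(-c2nn(CC#N)cc2-c2ccnc(-c3ccc(N(C)C)cc3)c2)c1`, has not yet been measured in this assay. It differs from compound 3 by hydrogen in place of methyl on an oxygen on an aromatic ring, so that the 3-methoxy-5-methylphenyl becomes 3-hydroxy-5-methylphenyl. Compound 2 carries that same hydroxy group on a different partner and gives a number, whereas compound 3 gives only a limit, which is all the two values show. For compound 4 the step from compound 3 is expected to be an at least 1.4-fold lower number from compound 3 to compound 4 (0.15 log units; that floor lies within the scatter), perhaps just beyond the scatter, because compound 3 sits at > 100000 nM. Compound 4 is thus estimated at 70000 nM, within 25000 nM to 200000 nM, with a real chance that this assay again returns only a limit.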

Compound 4, concentration lethal to 50% of the cells: > 100000 nM
Compound 4 gave a limit, no number; the forecaster's own chance of this, stated with the estimate: 45%; at least 1.4-fold (0.15 log units) between middle value and limit.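

Hydrogen in place of methyl on the oxygen leaves the read-out in this assay at a limit of the assay on both sides, so that step cannot be read, and the limit now holds most of the set: the limit of > 100000 nM in this assay, at which 3 of the 4 values shown sit. The hydroxy group alone therefore does not bring a number, since compound 4 carries it and still returns only a limit. Within the data shown here, with the 3-hydroxy-5-methylphenyl kept, dimethylamino in place of phenoxy on an aromatic carbon gives an at least 2.2-fold higher number from compound 2 to compound 4 (0.36 log units; beyond the scatter), the first readable step in the set, and it ties the only number here to the phenoxy partner.

From the compounds shown here alone, how far the limited compounds lie past the limit stays open, as does the effect of methoxy in place of hydroxy with the phenoxy partner. Going by these compounds, what a carboxylic acid or a longer alkoxy chain would do in place of phenoxy is also open.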